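Vero cytotoxicity: from compound 2 toward compound 3

The compounds below may be only part of what the source reports. "The series", "measured", "known", "first", "only" and "open" are said of these compounds alone.

Measured so far:
compound 1, `COc1cccc(CN2C(=O)CN(C(=O)c3cc4cc(OC)ccc4o3)C[C@@H]2CCc2ccccc2)c1`: 4500 nM
compound 2, `COc1ccc2[nH]c(C(=O)N3CC(=O)N(Cc4ccccc4)[C@@H](N4[C@H](C)CCC[C@@H]4C)C3)cc2c1`: 1400 nM

Of the compounds shown here, two have been tested in an ADME assay on Vero cells (Chlorocebus sabaeus) for cytotoxicity, with a stated time of 7 days; on this read-out higher numbers stand for lower toxicity in this test and lower numbers for higher toxicity in this test. Compound 1 gives 4500 nM in this assay, while compound 2 gives 1400 nM. Compound 2 therefore stands lowest of the two numbers; its nearest neighbour is compound 1, whose value is higher by a margin that lies beyond the usual scatter. Going by the values given here, the two structures differ in more than one place, so no single step between them can be drawn, and the account rests on the change now taken from compound 2.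

Compound 3, `COc1ccc2[nH]c(C(=O)N3CC(=O)N(Cc4ccccc4)[C@@H](CN4CCn5cccc5C4)C3)cc2c1`, is not yet measured. It differs from compound 2 as follows: a group of 10 heavy atoms (8 carbon, 2 nitrogen; one five-membered aromatic ring with 1 hetero atom, one six-membered non-aromatic ring with 2 hetero atoms) in place of a group of 8 heavy atoms (7 carbon, 1 nitrogen; one six-membered non-aromatic ring with 1 hetero atom), on a saturated ring carbon

Since no step between measured compounds is available, the size of the expected change in this assay cannot be anchored to a shown step; it is taken to be small, within or only slightly beyond the scatter, with a lean toward a higher number. Compound 3 is thus expected to give about 2500 nM in this assay, the estimated range running from 800 nM to 8000 nM, which means an expected step of a 1.8-fold higher number from compound 2 to compound 3 (0.25 log units; within the scatter).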

Compound 3, half-maximal cytotoxic concentration: > 100000 nM
Compound 3 gave a limit, no number; the forecaster's own chance of this, stated with the estimate: 15%; middle value at least 40-fold (1.60 log units) from the limit.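

In this assay, the group on a saturated ring carbon of the six-membered non-aromatic ring with 2 nitrogen turns out to matter greatly: replacing 2,6-dimethylpiperidin-1-yl with the group of 10 heavy atoms, which carries a five-membered aromatic ring and a six-membered non-aromatic ring, gives an at least 71-fold higher number from compound 2 to compound 3 (1.85 log units; beyond the scatter). Compound 3 gives no number in this test, only a limit: the limit of > 100000 nM in this assay, at which 1 of the 3 values shown sits. Compound 1 and compound 2 differ in more than one place and could not isolate any single change, whereas this step shows that exchanging this one group, with the rest of the structure held constant, can move the read-out far beyond the scatter, toward lower toxicity in this test.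

The compounds shown do not separate the contribution of the five-membered aromatic ring from that of the second ring nitrogen, nor do they tell whether the loss of the two methyl groups of the leaving group plays a part. On these data alone, how an unsubstituted piperidin-1-yl or a morpholin-4-yl group at this position would stand in this assay remains open.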